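Working notes: replacing the aromatic group on the shared core

The compounds below may be only part of what the source reports. "The series", "measured", "known", "first", "only" and "open" are said of these compounds alone.

- compound 1 `C=CS(=O)(=O)N1CCN(c2ncnc3sc(-c4cccc5ccccc45)cc23)CC1`: 28100 nM
- compound 2 `C=CS(=O)(=O)N1CCN(c2ncnc3sc(-c4cc(Br)cnc4F)cc23)CC1`: 28400 nM

Both values come from a functional assay on MDA-MB-436 cells (Homo sapiens) for antiproliferative activity, read by MTT assay, with a stated time of 48 h; on this read-out lower numbers stand for stronger inhibition and higher numbers for weaker inhibition. Among the compounds with values here, compound 2 gives 28400 nM and stands level with compound 1, the only other measured compound, so neither ranks ahead of the other.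

The next change leads to compound 3 `C=CS(=O)(=O)N1CCN(c2ncnc3sc(-c4cn(C)nc4C(F)(F)F)cc23)CC1`: 1-methyl-3-(trifluoromethyl)-1H-pyrazol-4-yl in place of 5-bromo-2-fluoropyridin-3-yl on an aromatic carbon. In words, 1-methyl-3-(trifluoromethyl)-1H-pyrazol-4-yl stands in place of 5-bromo-2-fluoropyridin-3-yl on an aromatic carbon, next to the ring sulfur.

Within the data shown here, one measured step bears on this, made at the same place: a 1.0-fold higher number from compound 1 to compound 2 (0.00 log units; within the scatter). There, naphthalen-1-yl gave way to 5-bromo-2-fluoropyridin-3-yl with no change beyond the scatter in this assay. A single step is thin evidence, but it gives no reason to expect a shift in either direction.

The expected step is a 1.0-fold lower number from compound 2 to compound 3 (0.01 log units; within the scatter), none beyond the scatter. For compound 3 the estimated value is 28000 nM, with an expected range of 11000 nM to 65000 nM.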

Compound 3, half-maximal inhibitory concentration: 15100 nM
Compound 3: middle estimate off by 1.9-fold (0.27 log units), on the high side; low and high end bracket the measured number.
By their numbers in this assay, from the lowest: compounds 3, 1 and 2 (each within the scatter of the next).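

In this assay, the steps at this position are a 1.9-fold lower number from compound 2 to compound 3 (0.27 log units; within the scatter) and a 1.9-fold lower number from compound 1 to compound 3 (0.27 log units; within the scatter), so all three compounds stand level. A five-membered aromatic ring with 2 hetero atoms therefore does not separate from either naphthalen-1-yl or 5-bromo-2-fluoropyridin-3-yl, and the level reading now spans three different aromatic groups on this carbon next to the ring sulfur. No measurement at hand accounts for this lack of separation.

As far as these compounds go, whether a non-aromatic group on this carbon, such as an amine or a carboxylic acid, would give a step beyond the scatter remains open. Also open, from the compounds shown here alone, is whether a change elsewhere on the shared core, such as an amide in place of the ethenesulfonyl group, would do so.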